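A few compounds are considered here, and "the series" means these few. Any claim that something is new, unique, unknown or untested is made for them only; others in the source may bear on it.

In an ADME assay on L02 cells (Homo sapiens) for cytotoxicity, read by MTT assay, with a stated time of 24 h (a lower number here means a stronger inhibitor, a higher number a weaker inhibitor), three compounds sharing one core have been measured. Compound 1 `CN1C/C(=C\c2cccnc2)C(=O)/C(=C/c2ccccc2F)C1` gives 15900 nM, compound 2 `O=C1/C(=C/c2cccnc2)CN(S(=O)(=O)c2ccc(Br)cc2)C/C1=C\c1ccccc1F` gives 14600 nM, and compound 3 `CC(=O)Nc1ccc(S(=O)(=O)N2C/C(=C\c3cccnc3)C(=O)/C(=C/c3ccccc3F)C2)cc1` gives 15600 nM. Compound 2 therefore stands level with the other two, as its number cannot be told apart from theirs.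

Compound 4 `O=C1/C(=C/c2cccnc2)CN(S(=O)(=O)c2ccc(Br)cc2)C/C1=C\c1ccccc1C(F)(F)F` differs from compound 2 in one place, with trifluoromethyl in place of fluoro on an aromatic carbon.

Two measured steps offer the nearest guide. One is a 1.1-fold lower number from compound 1 to compound 2 (0.04 log units; within the scatter), with (4-bromophenyl)sulfonyl in place of methyl on an amine nitrogen in a ring. The other is a 1.1-fold higher number from compound 2 to compound 3 (0.03 log units; within the scatter), with acetamido in place of bromo on an aromatic carbon. Neither touches the fluoro, so no measurement speaks to this change directly, and the guidance is indirect.

Going by those two small steps, no step beyond the scatter is expected in this assay, in either direction. The expected step is a 1.0-fold lower number from compound 2 to compound 4 (0.02 log units; within the scatter). For compound 4 the estimated value is 14000 nM, with an expected range from 7500 nM to 26000 nM.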

Compound 4, half-maximal inhibitory concentration: 13300 nM
Estimate against measurement, compound 4: 1.1-fold (0.02 log units) above; the range from low to high includes it.
By their numbers in this assay, from the lowest: compounds 4, 2, 3 and 1 (each within the scatter of the next).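

For the compounds shown here, the change from 2-fluorophenyl to 2-(trifluoromethyl)phenyl is the first in this set to touch this aromatic carbon, and in this assay it gives a 1.1-fold lower number from compound 2 to compound 4 (0.04 log units; within the scatter). At this position, then, a group of four heavy atoms can take the place of a single fluorine and leave the number within the scatter, as was also true of the two earlier changes made elsewhere on the molecule. No measurement here offers an explanation for this result.

As far as these compounds go, it remains open whether a different kind of group on this carbon, such as an amine, a carboxylic acid or a longer chain, would shift the number beyond the scatter. From the compounds shown here alone, it is also open whether 2-(trifluoromethyl)phenyl would give a similar number with methyl or another group in place of (4-bromophenyl)sulfonyl on the amine nitrogen in the ring.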